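Aryl group variation on the shared core: outlook for compound 3

A few compounds are considered here, and "the series" means these few. Any claim that something is new, unique, unknown or untested is made for them only; others in the source may bear on it.

Measured so far:
compound 1 `NS(=O)(=O)c1cccc(-c2nc(C(c3ccc(F)cc3)c3ccc(F)cc3)sc2CC(=O)O)c1`, in an in vitro functional assay on HEK285-7 cells for antagonist activity at prostaglandin D2 receptor 2 (Homo sapiens), read by BRET and beta-arrestin recruitment (on this read-out lower numbers stand for stronger inhibition and higher numbers for weaker inhibition), compound 1 gives 710 nM
compound 2 `O=C(O)Cc1sc(C(c2ccc(F)cc2)c2ccc(F)cc2)nc1-c1ccnc(O)c1`, in this assay compound 2 gives 890 nM

Within the data shown here, compound 2 holds the higher of the two numbers, but the only step in hand, a 1.3-fold higher number from compound 1 to compound 2 (0.10 log units; within the scatter), is within the scatter, so the two compounds are not separated by this assay. That step exchanges the aryl group on the same aromatic carbon of the shared core.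

Compound 3 `Nc1cc(-c2nc(C(c3ccc(F)cc3)c3ccc(F)cc3)sc2CC(=O)O)cc(F)n1` is not yet measured. It differs from compound 2 as follows: 2-amino-6-fluoropyridin-4-yl in place of 2-hydroxypyridin-4-yl on an aromatic carbon. Among the measured compounds shown here, the one measured step bears on the same place and was small. For the measured compounds named here, no step has moved the number beyond the scatter, so no shift beyond the scatter is expected, as a 1.1-fold lower number from compound 2 to compound 3 (0.05 log units; within the scatter). Compound 3 is estimated at 800 nM in this assay, with a range from 300 nM to 2500 nM.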

Compound 3, half-maximal inhibitory concentration: 1400 nM
Compound 3: middle estimate off by 1.8-fold (0.24 log units), on the low side; measured number inside the range.
By their numbers in this assay, from the lowest: compounds 1, 2 and 3 (each within the scatter of the next).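

In this assay, the aromatic carbon next to the ring nitrogen now holds a third aryl group, and exchanging 2-hydroxypyridin-4-yl for 2-amino-6-fluoropyridin-4-yl still gives no separation (a 1.6-fold higher number from compound 2 to compound 3 (0.20 log units; within the scatter)). The widest pair among the three also stays within the scatter (a 2.0-fold higher number from compound 1 to compound 3 (0.29 log units; within the scatter)), so 3-sulfamoylphenyl and both substituted pyridin-4-yl groups are not told apart at this position. The exchanged pyridine groups have the same counted hydrogen-bond donors and acceptors, and nothing available accounts for the values of compounds 1, 2 and 3.

As far as these compounds go, whether a non-aromatic group such as morpholine at this carbon would move the number beyond the scatter remains open. The compounds shown also leave open the effect of replacing the carboxymethyl group with a longer carboxylic acid chain.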